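Fluorophenyl Rearrangement and Expected Solubility

The compounds below may be only part of what the source reports. "The series", "measured", "known", "first", "only" and "open" are said of these compounds alone.

Compound 1 `C=CC(=O)Nc1cccc(-n2c(-c3nc(-c4cnn(C5CCN(C)CC5)c4)cnc3N)nc3ccccc32)c1`: in a physicochemical assay for solubility, at pH 7.4 (a lower number here means a less soluble compound, a higher number a more soluble compound), compound 1 gives < 10000 nM, which is a limit of the assay.
Compound 2 `C=CC(=O)Nc1ccc(F)c(-n2c(-c3nc(-c4cnn(C5CCN(C)CC5)c4)cnc3N)nc3ccccc32)c1`: in this assay compound 2 gives < 10000 nM, likewise a limit.

Compound 2 therefore stands only at a limit in this assay, and both values shown sit at the limit of < 10000 nM in this assay, at which 2 of the 2 values shown sit. Among the compounds with values here, the single measured step, a step that the two limits leave unreadable from compound 1 to compound 2, cannot be read from two limits. Compound 3 `C=CC(=O)Nc1cccc(-n2c(-c3nc(-c4cnn(C5CCN(C)CC5)c4)cnc3N)nc3ccccc32)c1F` differs from compound 2 by 2-fluoro-3-((vinylcarbonyl)amino)phenyl in place of 2-fluoro-5-((vinylcarbonyl)amino)phenyl on an aromatic nitrogen. Within the data shown here, no measured step bears on this rearrangement, so no direction can be set; compound 3 is expected to show a step that the limit leaves unreadable from compound 2 to compound 3, nothing beyond the scatter, with the limit likely reported again. Compound 3 is estimated at 5000 nM, within 1000 nM to 12000 nM.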

Compound 3, solubility: < 10000 nM
Compound 3 ended at the assay's limit; the forecaster's own chance of this, stated with the estimate: 80%; the middle value does not contradict the limit.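

Neither the step from compound 2 to compound 3 nor the one from compound 1 to compound 3 can be read in this assay, where compound 3 also stands at a limit: the limit of < 10000 nM in this assay, at which 3 of the 3 values shown sit.

The compounds shown leave open how the three compare in this assay, and whether either change makes any difference there.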